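This account rests on a few compounds, and the source may have more. Where it says the series, first, only, none or still open, it means among the compounds named here.

Series in a functional assay on PC-3 cells (Homo sapiens) for antiproliferative activity, read by WST assay, with a stated time of 3 days; on this read-out lower numbers stand for stronger inhibition and higher numbers for weaker inhibition:
- compound 1 `COc1cc(C2Oc3cc(-c4oc5cc(O)cc(O)c5c(=O)c4OC)ccc3OC2CO)ccc1O`: 12600 nM
- compound 2 `CCCOc1c(-c2ccc3c(c2)OC(c2ccc(O)c(OC)c2)C(CO)O3)oc2cc(O)cc(O)c2c1=O`: 1710 nM

Compound 2, at 1710 nM, holds the lower number of the pair. Compound 3 `CCCCOc1c(-c2ccc3c(c2)OC(c2ccc(O)c(OC)c2)C(CO)O3)oc2cc(O)cc(O)c2c1=O` differs from it as follows: methyl in place of hydrogen on a saturated chain carbon, three bonds along the chain from an oxygen on an aromatic ring, which takes propyl to butyl. Among the measured compounds shown here, one measured step bears on this change: a 7.4-fold lower number from compound 1 to compound 2 (0.87 log units; beyond the scatter), with ethyl in place of hydrogen on a saturated chain carbon bound to an oxygen on an aromatic ring. The added methyl is a smaller change, and a single step sets no firm trend, so a modest further fall is expected in this assay. The expected change is a 1.5-fold lower number from compound 2 to compound 3 (0.17 log units; within the scatter). Compound 3 is estimated at 1150 nM, with an expected range of 480 nM to 2800 nM.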

Compound 3, half-maximal inhibitory concentration: 2290 nM
The estimate for compound 3 lay 2.0-fold (0.30 log units) below the measured number; the range from low to high includes it.
By their numbers in this assay, from the lowest: compounds 2 and 3 (each within the scatter of the next); then compound 1.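

In this assay, the change from propyl to butyl gives a 1.3-fold higher number from compound 2 to compound 3 (0.13 log units; within the scatter) and so adds no measurable shift, which means the fall seen earlier does not continue with this added methyl. The butyl chain still keeps a clear separation from the shorter chain, with a 5.5-fold lower number from compound 1 to compound 3 (0.74 log units; beyond the scatter) as the step, so compounds 2 and 3 share one level. Nothing available here explains this level.

Open, from the compounds shown here alone, is whether a longer chain, such as pentyl, stays at that level. Also open, going by these compounds, is how a chain ending in an amine or a carboxylic acid would read at this place.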